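This account rests on a few compounds, and the source may have more. Where it says the series, first, only, none or still open, it means among the compounds named here.

In an assay on cells for agonist activity at vitamin D3 receptor (Homo sapiens), with a stated time of 96 h (on this read-out higher numbers stand for an effect only at larger amounts of compound and lower numbers for an effect already at smaller amounts), compound 1 `CCn1c(C(=O)NCC#N)ccc1C(CC)(CC)c1ccc(OCCC(O)(CC)CC)c(C)c1` gives 1080 nM, the highest of the two plain numbers in this small set. Compound 2 `CCn1c(C(=O)NCCN)ccc1C(CC)(CC)c1ccc(OCCC(O)(CC)CC)c(C)c1` gives 156 nM. Compound 3 `CCn1c(C(=O)Nc2ccc(OC(F)(F)F)cc2)ccc1C(CC)(CC)c1ccc(OCCC(O)(CC)CC)c(C)c1` is reported only as a limit of the assay, > 10000 nM, namely (the limit of > 10000 nM in this assay, at which 1 of the 3 values shown sits). Compound 4 `CCOC(=O)CN(C)C(=O)c1ccc(C(CC)(CC)c2ccc(OCCC(O)(CC)CC)c(C)c2)n1CC` has not been measured yet; it differs from compound 1 in one place: ((ethoxycarbonyl)methyl)(methyl)amino in place of (cyanomethyl)amino on a carbonyl carbon. Both measured steps also change the group on the amide nitrogen of compound 1. One step, a 6.9-fold lower number from compound 1 to compound 2 (0.84 log units; beyond the scatter), improved potency; the other, an at least 9.2-fold higher number from compound 1 to compound 3 (0.96 log units; beyond the scatter), weakened it. Compound 4 carries the heavier of the two new groups and, as counted, no hydrogen-bond donor, so its change resembles the direction of compound 3 more than that of compound 2, and a weakening is expected: a 2.8-fold higher number from compound 1 to compound 4 (0.44 log units; beyond the scatter). Compound 4 is therefore estimated at 3000 nM, with a likely range from 800 nM to 12000 nM.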

Compound 4, half-maximal effective concentration: 520 nM
The estimate for compound 4 lay 5.8-fold (0.76 log units) above the measured number; the whole stated range lies above it.
By their numbers in this assay, from the lowest: compound 2; then compound 4; then compound 1. At a limit, above all of these: compound 3.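

The amide nitrogen on this carbonyl carbon tolerates a larger group with no hydrogen-bond donor: in this assay the change gives a 2.1-fold lower number from compound 1 to compound 4 (0.32 log units; beyond the scatter) and does not weaken the effect. Even so, the 2-aminoethyl group of compound 2 remains ahead, as the reverse comparison gives a 3.3-fold higher number from compound 2 to compound 4 (0.52 log units; beyond the scatter) and shows. Compound 3 is reported only as a limit, > 10000 nM, and an at least 19-fold lower number from compound 3 to compound 4 (1.28 log units; beyond the scatter) shows that the loss seen with its 4-(trifluoromethoxy)phenyl group does not extend to every larger group here.

The ethoxycarbonyl part and the added methyl entered together, so a (cyanomethyl)(methyl)amino group or the free carboxylic acid in place of the ethyl ester would be needed to separate them. Nothing shown explains why this change moved the number as it did.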